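Little Left After Methoxy Swap? An Expected Outcome

The source may report more compounds than this note shows. Statements on the series, on what has been measured and on what is new or still open speak of the compounds shown alone.

Measured in an ADME assay on microsomes from liver (Homo sapiens) for metabolic stability, read by LC-MS, with a stated time of 15 min; a higher number here means that more of the compound is left, a lower number that less of the compound is left:
compound 1 `CCNC(=O)Nc1sc2ccccc2c1C(=O)N1CCN(C2CCN(C(=O)OC(C)(C)CF)CC2)CC1`: 3%
compound 2 `CCNC(=O)Nc1sc2cc(C(F)(F)F)ccc2c1C(=O)N1CCN(C2CCN(C(=O)C(C)(C)C(F)(F)F)CC2)CC1`: 7%
compound 3 `CCNC(=O)Nc1sc2cc(F)ccc2c1C(=O)N1CCN(C2CCN(C(=O)C(C)(C)C(F)(F)F)CC2)CC1`: 17%

In this assay, compound 3 gives 17%. Compound 1 gives 3%, and compound 2 gives 7%. The gap between compound 3 and compound 1 lies beyond the usual scatter, while the gap between compound 3 and compound 2 lies within it.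

The next compound, compound 4 `CCNC(=O)Nc1sc2cc(OC)ccc2c1C(=O)N1CCN(C2CCN(C(=O)C(C)(C)C(F)(F)F)CC2)CC1`, carries methoxy in place of fluoro on an aromatic carbon. The rest of its structure matches compound 3.

Among the measured compounds shown here, only one measured step bears on this change. It replaces a different group at the same aromatic carbon, and it is a number 10 percentage points higher from compound 2 to compound 3 (within the scatter). That step gives no sign of a large effect from a change at this carbon, although methoxy itself has not yet been measured here. No step beyond the scatter is therefore expected in this assay, and the expected change is a number 6 percentage points lower from compound 3 to compound 4 (within the scatter). For compound 4 the estimated value is 11%, with an expected range from 3% to 26%.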

Compound 4, percent of the compound remaining: 29%
Beside the measured number, compound 4's estimate is 18 percentage points below it; the whole stated range lies below it.
By their numbers in this assay, from the lowest: compounds 1, 2 and 3 (each within the scatter of the next, the first and the last beyond it); then compound 4.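

At this aromatic carbon, the choice of group does register in this assay: methoxy in place of fluoro gives a number 12 percentage points higher from compound 3 to compound 4 (beyond the scatter) and methoxy in place of trifluoromethyl gives a number 22 percentage points higher from compound 2 to compound 4 (beyond the scatter) while the earlier step, a number 10 percentage points higher from compound 2 to compound 3 (within the scatter) left fluoro and trifluoromethyl unseparated. Methoxy therefore stands apart from both of the other groups tested at this carbon, a difference the earlier compounds could not show. Nothing measured here points to a cause for this difference.

From the compounds shown here alone, it remains open whether a hydroxyl group, an ethoxy chain or an amine at this carbon would read like methoxy. Also open, going by these compounds, is whether methoxy would give a similar step on a compound carrying the different group found at the far end of compound 1.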